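The source may hold more compounds than are shown below. What is called first, only, known or untested is meant among the compounds shown, and "the series" means these compounds.

Measured in a functional assay on NCI-H661 cells (Homo sapiens) for inhibition, read by MTT assay, with a stated time of 72 h; a higher number here means a weaker inhibitor, a lower number a stronger inhibitor:
- Compound 1 `Nc1ccccc1NC(=O)c1ccc(CNCc2nc(-c3ccc(C(F)(F)F)cc3)no2)cc1`: 23500 nM
- Compound 2 `O=C(NO)c1ccc(CNCc2nc(-c3ccccc3)no2)cc1`: > 100000 nM (a limit of the assay, not a number)

Compound 2 has no numerical reading in this assay, and its > 100000 nM is a limit. From the compounds shown here alone, its true position therefore remains open, with only that limit to go on.

Compound 3 `O=C(NO)c1ccc(CNCc2nc(-c3ccc(C(F)(F)F)cc3)no2)cc1` follows from compound 2 by placing trifluoromethyl in place of hydrogen on an aromatic carbon, para to a large group (trifluoromethyl in place of hydrogen on an aromatic carbon). Among the measured compounds shown here, compound 1 also bears trifluoromethyl and gives 23500 nM, and this single value is the only guide to the expectation. A modest move toward stronger inhibition is expected, and the reading may again prove to be only a limit. The expected change is an at least 1.6-fold lower number from compound 2 to compound 3 (0.22 log units; that floor lies within the scatter). For compound 3 the estimated value is 60000 nM, with an expected range of 15000 nM to 150000 nM.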

Compound 3, half-maximal inhibitory concentration: > 100000 nM
Compound 3 was reported as a limit; the forecaster's own chance of this, stated with the estimate: 45%; middle value at least 1.6-fold (0.22 log units) from the limit.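

In this assay compound 3 gives > 100000 nM, which is a limit of the assay and not a number. The step that places trifluoromethyl on the aromatic carbon cannot be read, because both of its ends rest on the same limit: the limit of > 100000 nM in this assay, at which 2 of the 3 values shown sit.

With trifluoromethyl held in common, the change on the other side can be read: hydroxy in place of 2-aminophenyl on an amide-type nitrogen gives an at least 4.2-fold higher number from compound 1 to compound 3 (0.62 log units; beyond the scatter).

From the compounds shown here alone, whether trifluoromethyl has any effect on this series remains open, and so does how the 2-aminophenyl amide would read with hydrogen in its place. Also open, going by these compounds, is whether chlorine or methoxy on that aromatic carbon, or an amine or a longer chain on the amide-type nitrogen, would give a numerical reading.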